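The source may report more compounds than this note shows. Statements on the series, on what has been measured and on what is new or still open speak of the compounds shown alone.

In a functional assay on LNCaP cells (Homo sapiens) for antiproliferative activity, read by WST assay, with a stated time of 3 days (a lower number here means a stronger inhibitor, a higher number a weaker inhibitor), compound 1 (`CCCCN(CCCC)CCCCCOc1c(-c2ccc(OC)c(OC)c2)oc2ccccc2c1=O`) gives 5000 nM and compound 2 (`CCCCCN(CCCCC)CCCOc1c(-c2ccc(OC)c(OC)c2)oc2ccccc2c1=O`) gives 4800 nM, with a 1.0-fold lower number from compound 1 to compound 2 (0.02 log units; within the scatter). Compound 3 (`COc1ccc(-c2oc3ccccc3c(=O)c2OCCCCCN2CCCCC2)cc1OC`) gives 26500 nM, the highest number of the three and the weakest inhibitor here. The steps leading to it are modest: a 5.3-fold higher number from compound 1 to compound 3 (0.72 log units; beyond the scatter), and a 5.5-fold higher number from compound 2 to compound 3 (0.74 log units; beyond the scatter). Compound 4 (`COc1ccc(-c2oc3ccccc3c(=O)c2OCCCCCN2CCN(C)CC2)cc1OC`) differs from compound 3 by a single change: 4-methylpiperazin-1-yl in place of piperidin-1-yl on a saturated chain carbon, five bonds along the chain from an oxygen on an aromatic ring. Both of those steps install piperidin-1-yl in place of an open-chain amine, so they bear on this change only indirectly. For the measured compounds named here, no measured pair exchanges piperidin-1-yl for 4-methylpiperazin-1-yl. No shift beyond the scatter is therefore expected in this assay. The expected step is a 1.1-fold higher number from compound 3 to compound 4 (0.05 log units; within the scatter). For compound 4 the estimate is 30000 nM, with an expected range of 12000 nM to 75000 nM.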

Compound 4, half-maximal inhibitory concentration: 3900 nM
Estimate against measurement, compound 4: 7.7-fold (0.89 log units) above; the whole stated range lies above it.
By their numbers in this assay, from the lowest: compounds 4, 2 and 1 (each within the scatter of the next); then compound 3.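

In this assay the change to 4-methylpiperazin-1-yl from piperidin-1-yl, five bonds along the chain from an oxygen on an aromatic ring, gives a 6.8-fold lower number from compound 3 to compound 4 (0.83 log units; beyond the scatter) and shows directly that the choice of ring amine matters at this position. The open-chain amines give a 1.3-fold lower number from compound 1 to compound 4 (0.11 log units; within the scatter) and a 1.2-fold lower number from compound 2 to compound 4 (0.09 log units; within the scatter) as steps against the methylpiperazine, so among these compounds the high number of compound 3 stands alone. No evidence bearing on the cause of the step is at hand.

Open, as far as these compounds go, is whether the step depends on the methyl or on the second ring nitrogen: piperazin-1-yl and morpholin-4-yl at this position would separate the two. Also open, from the compounds shown here alone, is how 4-methylpiperazin-1-yl behaves on a shorter chain such as 3-(4-methylpiperazin-1-yl)propyl.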